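A dichlorophenyl to dimethoxyphenyl swap on the carbonyl

This account rests on a few compounds, and the source may have more. Where it says the series, first, only, none or still open, it means among the compounds named here.

Compound 1 `COc1cc(-c2cc(/C=C/C(=O)c3ccc(Cl)c(Cl)c3)[nH]n2)cc(OC)c1OC` carries a 3,4-dichlorophenyl group on its carbonyl carbon. In a functional assay on OVCAR-3 cells (Homo sapiens) for inhibition, read by sulforhodamine B assay, with a stated time of 48 h (on this read-out lower numbers stand for higher toxicity in this test and higher numbers for lower toxicity in this test), compound 1 reaches only a limit, > 100000 nM, and not a number. Of the three values measured, compound 1 is the one that sits at this limit (the limit of > 100000 nM in this assay, at which 1 of the 3 values shown sits).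

Two other compounds from the same series did give numbers. Compound 2 `COc1ccc(-c2cc(/C=C/C(=O)c3ccc(N)cc3)[nH]n2)cc1OC` gives 9140 nM in this assay. Compound 3 `COc1ccc(-c2cc(/C=C/C(=O)c3cc(OC)c(OC)c(OC)c3)[nH]n2)cc1OC` gives 6230 nM in this assay. Both of these carry a 3,4-dimethoxyphenyl group, and both ended up with a measurable value rather than a limit.

Compound 4 `COc1ccc(C(=O)/C=C/c2cc(-c3cc(OC)c(OC)c(OC)c3)n[nH]2)cc1OC` is the compound not yet measured. It differs from compound 1 in a single place: 3,4-dimethoxyphenyl in place of 3,4-dichlorophenyl on a carbonyl carbon. For the measured compounds named here, no pair of measured compounds differs in just one place, so no measured step shows directly what this exchange does; the expectation rests on compound 1 sitting at its limit while compound 2 and compound 3 give numbers. The step from compound 1 to compound 4 is expected to be an at least 6.6-fold lower number from compound 1 to compound 4 (0.82 log units; beyond the scatter), in the direction of higher toxicity. Compound 4 is estimated at 15000 nM, with a range from 4000 nM to 100000 nM, and a real chance remains that it too reaches only a limit.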

Compound 4, concentration lethal to 50% of the cells: 5970 nM
Estimate against measurement, compound 4: 2.5-fold (0.40 log units) above; the range from low to high includes it.
By their numbers in this assay, from the lowest: compounds 4, 3 and 2 (each within the scatter of the next). At a limit, above all of these: compound 1.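

For the compounds shown here, this pair is the first in which only one place changes, so the effect of the group on the carbonyl carbon can be read directly. Putting 3,4-dimethoxyphenyl in place of 3,4-dichlorophenyl gives an at least 16-fold lower number from compound 1 to compound 4 (1.22 log units; beyond the scatter) in this assay, a large change in the direction of higher toxicity, and the rest of the molecule stays the same. The full size of this step remains unknown because compound 1 gives a limit of the assay and not a number: the limit of > 100000 nM in this assay, at which 1 of the 4 values shown sits.

The compounds shown leave open whether the result comes from removing the two chlorine atoms or from adding the two methoxy groups, and an unsubstituted phenyl group on the same carbonyl carbon would help to separate these two possibilities. Going by these compounds, it also remains open how far this one exchange carries over to other compounds, since a single pair cannot show whether the same change would have a similar effect on a different core or whether other groups at this place, such as 3,4-dihydroxyphenyl, would behave like 3,4-dimethoxyphenyl.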